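The source may report more compounds than this note shows. Statements on the series, on what has been measured and on what is new or still open speak of the compounds shown alone.

Three quinazoline ureas have been measured so far. Compound 1 `O=C(Nc1ccc(CN2CCCCC2)cc1)Nc1ccc2ncnc(Nc3cccc(C(F)(F)F)c3)c2c1` gives 1050 nM in a functional assay on A549 cells (Homo sapiens) for antiproliferative activity, read by MTT assay, with a stated time of 72 h; a higher number here means a weaker inhibitor, a lower number a stronger inhibitor. Compound 2 `CCN(CC)Cc1ccc(NC(=O)Nc2ccc3ncnc(Nc4cccc(C(F)(F)F)c4)c3c2)cc1` carries a diethylamino group where compound 1 has a piperidin-1-yl group, and in this assay compound 2 gives 2070 nM; the change a 2.0-fold higher number from compound 1 to compound 2 (0.29 log units; within the scatter) is small. Compound 3 `O=C(Nc1cccc(CN2CCCCC2)c1)Nc1ccc2ncnc(Nc3cccc(C(F)(F)F)c3)c2c1`, which places the (piperidin-1-yl)methyl group at a different point of the outer ring, gives 1060 nM in this assay. Compound 3 therefore sits with compound 1 and compound 2 inside the usual scatter of this assay, and no order among the three can be read from the numbers.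

Compound 4 `O=C(Nc1ccccc1)Nc1ccc2ncnc(Nc3cccc(C(F)(F)F)c3)c2c1` is not yet measured. It differs from compound 3 by hydrogen in place of (piperidin-1-yl)methyl on an aromatic carbon, so the whole side group, not merely the amine within it, is gone. Among the measured compounds shown here, the only measured step, that from compound 1 to compound 2, swaps one amine for another and leaves the chain in place; it stays within the scatter and gives no direct guide to removing the group altogether. The expectation is therefore a modest loss of activity with wide uncertainty: compound 4 is estimated at 2500 nM, within 700 nM to 9000 nM, a step of a 2.4-fold higher number from compound 3 to compound 4 (0.37 log units; beyond the scatter) from compound 3 to compound 4.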

Compound 4, half-maximal inhibitory concentration: > 10000 nM
Compound 4: a limit, no number; the forecaster's own chance of this, stated with the estimate: 10%; at least 4.0-fold (0.60 log units) between middle value and limit.
By their numbers in this assay, from the lowest: compounds 1, 3 and 2 (each within the scatter of the next). At a limit, above all of these: compound 4.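

Compound 4 stands at a limit of the assay, not at a number: the limit of > 10000 nM in this assay, at which 1 of the 4 values shown sits. In this assay, removing the whole side group weighs far more than exchanging the amine within it: the steps are an at least 9.4-fold higher number from compound 3 to compound 4 (0.97 log units; beyond the scatter), an at least 9.5-fold higher number from compound 1 to compound 4 (0.97 log units; beyond the scatter) and an at least 4.8-fold higher number from compound 2 to compound 4 (0.68 log units; beyond the scatter), all of them resting on that limit, whereas a 2.0-fold higher number from compound 1 to compound 2 (0.29 log units; within the scatter) stays small. Among these four compounds, then, activity on the outer ring depends on having a side group there at all, while the choice between (piperidin-1-yl)methyl and (diethylamino)methyl shows no change beyond the scatter.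

The compounds shown leave open whether the amine nitrogen itself is what counts or whether the carbon atoms around it would serve as well; a cyclohexylmethyl group, which keeps a six-membered ring but carries no amine, would separate the two. They also leave open what a longer chain carrying the amine, or a morpholine in place of the piperidine, would do to the number in this assay.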